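Swapping the Pentylamino Arm of a Purine Riboside

The source may report more compounds than this note shows. Statements on the series, on what has been measured and on what is new or still open speak of the compounds shown alone.

Among the three compounds with numbers in hand, compound 1 `CCCCCNc1ncnc2c1ncn2[C@@H]1O[C@H](CO)[C@@H](O)[C@H]1O` is the strongest inhibitor: in an assay on isolated protein for binding affinity to Equilibrative nucleoside transporter 1 (Homo sapiens) (on this read-out higher numbers stand for weaker inhibition and lower numbers for stronger inhibition), compound 1 gives 13500 nM. The nearest of the other two is compound 3 `CSc1ncnc2c1ncn2C1CCCCO1`, which gives 275000 nM in this assay, and the furthest is compound 2 `Nc1ncnc2c1ncn2[C@@H]1O[C@H](COCCOCCNc2ncnc3c2ncn3[C@@H]2O[C@H](CO)[C@@H](O)[C@H]2O)[C@@H](O)[C@H]1O`, which gives 912000 nM in this assay; both gaps lie well beyond the scatter.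

Compound 4 `OC[C@H]1O[C@@H](n2cnc3c(CSc4ccccc4Br)ncnc32)[C@H](O)[C@@H]1O` has not yet been measured. It differs from compound 1 in a single place: ((2-bromophenyl)sulfanyl)methyl in place of pentylamino on an aromatic carbon. Within the data shown here, no pair of measured compounds differs in this same way, so the size of the step cannot be read directly from the data; compounds 2 and 3 carry neither a pentylamino nor a ((2-bromophenyl)sulfanyl)methyl group. Compound 4 is expected to give about 5000 nM in this assay, within a range from 800 nM to 30000 nM. The step of a 2.7-fold lower number from compound 1 to compound 4 (0.43 log units; beyond the scatter) is estimated as a modest gain in inhibition, though it may well fall within the scatter.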

Compound 4, half-maximal inhibitory concentration: 2400 nM
Estimate against measurement, compound 4: 2.1-fold (0.32 log units) above; the measured number falls inside the stated range.
By their numbers in this assay, from the lowest: compound 4; then compound 1; then compound 3; then compound 2.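

In this assay, the step of a 5.6-fold lower number from compound 1 to compound 4 (0.75 log units; beyond the scatter) shows that this aromatic carbon accepts a ((2-bromophenyl)sulfanyl)methyl group, with its six-membered aromatic ring of carbon only, in place of the pentylamino arm, and that inhibition improves modestly. The entering group also has no hydrogen-bond donor, so in this one pair the donor of the pentylamino arm is not needed for inhibition at this level. The data at hand offer no measurement that explains the gain.

The change replaces the chain, the sulfur and the bromine-bearing ring at once, so these compounds do not show which part accounts for the step. An unsubstituted phenylsulfanylmethyl group, or a 2-chlorophenyl or 2-methoxyphenyl ring on the same sulfanylmethyl link, would separate these parts.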